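The source may report more compounds than this note shows. Statements on the series, on what has been measured and on what is new or still open speak of the compounds shown alone.

Working notes on the series. Among the compounds with values here, the three compounds measured so far share one core and differ by a single aromatic substituent. Compound 1 `O=C(/C=C/c1ccccc1)c1ccc(N2C(=O)C=CC2=O)cc1` gives 8600 nM in a functional assay on L1210 cells (Mus musculus) for cytotoxicity; on this read-out higher numbers stand for weaker inhibition and lower numbers for stronger inhibition. Compound 2 `O=C(/C=C/c1ccc(Cl)cc1)c1ccc(N2C(=O)C=CC2=O)cc1` carries chloro in place of hydrogen and gives 7300 nM in this assay; the step of a 1.2-fold lower number from compound 1 to compound 2 (0.07 log units; within the scatter) is within the scatter. Compound 3 `COc1ccc(/C=C/C(=O)c2ccc(N3C(=O)C=CC3=O)cc2)cc1` carries methoxy in place of hydrogen and gives 9800 nM in this assay. Its number is the highest of the three, but both a 1.1-fold higher number from compound 1 to compound 3 (0.06 log units; within the scatter) and a 1.3-fold higher number from compound 2 to compound 3 (0.13 log units; within the scatter) stay within the scatter, so no order among the three can be read from these data.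

Compound 4 `COc1ccc(/C=C/C(=O)c2ccc(N3C(=O)C=CC3=O)cc2)cc1OC` is not yet measured. Its structure differs from compound 3 by methoxy in place of hydrogen on an aromatic carbon. The step that bears most directly on this change is a 1.1-fold higher number from compound 1 to compound 3 (0.06 log units; within the scatter), the same exchange of hydrogen for methoxy on the same ring, which produced no movement beyond the scatter; the other two steps, a 1.2-fold lower number from compound 1 to compound 2 (0.07 log units; within the scatter) and a 1.3-fold higher number from compound 2 to compound 3 (0.13 log units; within the scatter), were equally flat. Within the data shown here, nothing so far suggests that a second methoxy should behave differently, so the expected step of a 1.0-fold higher number from compound 3 to compound 4 (0.01 log units; within the scatter) is none beyond the scatter. For compound 4 the estimated value in this assay is 10000 nM, with a range from 5000 nM to 20000 nM.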

Compound 4, half-maximal inhibitory concentration: 157000 nM
Beside the measured number, compound 4's estimate is 16-fold (1.20 log units) below it, and the stated range ends below it.
By their numbers in this assay, from the lowest: compounds 2, 1 and 3 (each within the scatter of the next); then compound 4.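

In this assay, the exchange of hydrogen for methoxy at this position, ortho to a methoxy group and meta to a large group, is far from neutral (a 16-fold higher number from compound 3 to compound 4 (1.20 log units; beyond the scatter)). The same kind of exchange stayed within the scatter on the core of compound 1 (a 1.1-fold higher number from compound 1 to compound 3 (0.06 log units; within the scatter)), so the flat picture from the first three compounds does not extend to this position, and the effect of a methoxy in this series cannot be taken as independent of where it stands or of what else the ring carries. Nothing available here accounts for the rise in the number.

The compounds shown leave open whether the rise belongs to this position alone or to the two methoxy groups together: each compound with a methoxy at this position also carries the other methoxy, so the two contributions cannot be separated. Also open, on these data alone, is whether a smaller or larger group here, such as a hydroxyl, an amine or a longer ether chain like ethoxy, would give a number close to that of compound 3 or of compound 4.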